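Replacing the pentenoyl chain of compound 1 with a selenocyanate

The source may report more compounds than this note shows. Statements on the series, on what has been measured and on what is new or still open speak of the compounds shown alone.

Measured compounds:
compound 1, `CCC/C=C/C(=O)N(Cc1ccc(OC)c(O)c1)c1cc(OC)c(OC)c(OC)c1`: 95 nM
compound 2, `COc1ccc(N(Cc2cc(OC)c(OC)c(OC)c2)C(=O)CCl)cc1O`: 22500 nM

In a functional assay on HCT-116 cells (Homo sapiens) for inhibition, read by MTT assay, with a stated time of 48 h (a higher number here means a weaker inhibitor, a lower number a stronger inhibitor), compound 1 gives 95 nM, the lowest of the two numbers recorded. Compound 2 is the nearest neighbour, and in this assay compound 2 gives 22500 nM, a gap far beyond the scatter.

Compound 3, `COc1ccc(CN(C(=O)C[Se]C#N)c2cc(OC)c(OC)c(OC)c2)cc1O`, has not yet been measured in this assay. Compared with compound 1 the change is a group of 4 heavy atoms (2 carbon, 1 nitrogen, 1 selenium; no ring) in place of a group of 5 heavy atoms (5 carbon; no ring), on a carbonyl carbon.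

Among the compounds with values here, no step between measured compounds isolates this change. Compound 2, which carries a different group on the same carbonyl carbon, stands well above compound 1, so a weakening step from compound 1 to compound 3 is expected, an 11-fold higher number from compound 1 to compound 3 (1.02 log units; beyond the scatter), in the direction of weaker inhibition but not as large. For compound 3 the estimated value in this assay is 1000 nM, within a range from 200 nM to 8000 nM.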

Compound 3, half-maximal inhibitory concentration: 310 nM
For compound 3 the middle estimate is 3.2-fold (0.51 log units) above the measured one; low and high end bracket the measured number.
By their numbers in this assay, from the lowest: compound 1; then compound 3; then compound 2.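

In this assay, this is the first step shown that changes only the group on the carbonyl carbon, and it gives a 3.3-fold higher number from compound 1 to compound 3 (0.51 log units; beyond the scatter) as the sole reading of this exchange. The pent-1-en-1-yl group, with its double bond, can therefore give way to a selenium-bearing group with a triple bond at only a modest cost, so the carbon chain of compound 1 is not required for activity in this assay. Nothing measured here accounts for the size of this step.

As far as these compounds go, whether the selenium atom or the nitrile end matters more remains open, since a thiocyanate on the same carbonyl carbon would be needed to separate them. From the compounds shown here alone, how a saturated pentyl chain or a longer chain would compare with compound 1 also remains open.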